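From an octyl chain to a (thiophen-2-yl)carbonyl group

The source may report more compounds than this note shows. Statements on the series, on what has been measured and on what is new or still open speak of the compounds shown alone.

compound 1 `Cn1nc(-c2cccnc2)c2ccccc2c1=O`: 11500 nM in a functional assay (trachea) with Cavia porcellus as the target; on this read-out lower numbers stand for stronger inhibition and higher numbers for weaker inhibition
compound 2 `CCCCCCCCn1nc(-c2cccnc2)c2ccccc2c1=O`: 21900 nM
compound 3 `CCOC(=O)Cn1nc(-c2cccnc2)c2ccccc2c1=O`: 43700 nM

Of the compounds shown here, three sharing one core have been measured in this assay. Within the data shown here, compound 2 sits between the other two on these numbers: the step of a 1.9-fold higher number from compound 1 to compound 2 (0.28 log units; within the scatter) and the step of a 2.0-fold higher number from compound 2 to compound 3 (0.30 log units; within the scatter) are both within the scatter, and only the step of a 3.8-fold higher number from compound 1 to compound 3 (0.58 log units; beyond the scatter) reaches beyond it. All three differ solely in what hangs from the saturated chain carbon bound to the aromatic nitrogen.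

Compound 4 `O=C(c1cccs1)n1nc(-c2cccnc2)c2ccccc2c1=O` is not yet measured. Relative to compound 2 the change is (thiophen-2-yl)carbonyl in place of octyl on an aromatic nitrogen. Among the measured compounds shown here, no measured step removes the chain carbon itself or places a carbonyl on the aromatic nitrogen, so the three measured steps bear on it only loosely; they show that changes at this end of the molecule have so far moved the number little, at most modestly upward. Compound 4 is therefore expected to land near compound 2, with a step of a 1.1-fold higher number from compound 2 to compound 4 (0.06 log units; within the scatter) and a broad range: the estimate for compound 4 is 25000 nM, between 7000 nM and 90000 nM.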

Compound 4, half-maximal inhibitory concentration: 12300 nM
The estimate for compound 4 lay 2.0-fold (0.31 log units) above the measured number; measured number inside the range.
By their numbers in this assay, from the lowest: compounds 1, 4, 2 and 3 (each within the scatter of the next, the first and the last beyond it).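

In this assay a (thiophen-2-yl)carbonyl group, which puts a carbonyl and an aromatic ring directly on the aromatic nitrogen, reads no differently from the simple alkyl groups: a 1.8-fold lower number from compound 2 to compound 4 (0.25 log units; within the scatter) and a 1.1-fold higher number from compound 1 to compound 4 (0.03 log units; within the scatter) both lie within the scatter. Against the (ethoxycarbonyl)methyl group the same exchange goes beyond the scatter, with a 3.6-fold lower number from compound 3 to compound 4 (0.55 log units; beyond the scatter), a modest step, so this position accepts a group very unlike an alkyl chain without any loss relative to compound 1 or compound 2. No evidence is available that explains these numbers.

The compounds shown leave open how an amine or a carboxylic acid at the end of a chain on this nitrogen would read, and whether a phenyl ring in place of the thiophene would change the number. They also leave open what the pyridin-3-yl group contributes, as it stays the same throughout.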